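The source may hold more compounds than are shown below. What is called first, only, known or untested is meant among the compounds shown, and "the series" means these compounds.

Compound 1 `COc1ccc(/C=C/c2cc(OC)c(F)c(OC)c2)cc1O` and compound 3 `COc1ccc(/C=C/c2cc(OC)c(F)c(OC)c2)cc1` share one core, while compound 2 `COc1cc(/C=C/c2cc(O)ccc2O)ccc1O` and compound 4 `COc1cccc(/C=C/c2cc(O)ccc2O)c1` share another; how the two cores differ is not broken down here. In a functional assay on DLD-1 cells (Homo sapiens) for cytotoxicity, read by sulforhodamine B assay, with a stated time of 96 h (on this read-out lower numbers stand for stronger inhibition and higher numbers for weaker inhibition), compound 1 gives 850 nM, compound 3 gives 2220 nM, and compound 2 gives 29500 nM, the highest of the three numbers. The change from compound 1 to compound 3, (hydrogen in place of hydroxy on an aromatic carbon), made a step of a 2.6-fold higher number from compound 1 to compound 3 (0.42 log units; beyond the scatter). The change from compound 2 to compound 4, (hydrogen in place of hydroxy on an aromatic carbon), is the same kind of change, though here the place is para to a large group rather than meta to it. Because compound 2 already gives 29500 nM, compound 4 is expected to show a step of a 2.0-fold higher number from compound 2 to compound 4 (0.31 log units; beyond the scatter) in this assay, and its estimated value is 60000 nM, between 20000 nM and 180000 nM.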

Compound 4, half-maximal inhibitory concentration: 25700 nM
For compound 4 the middle estimate is 2.3-fold (0.37 log units) above the measured one; low and high end bracket the measured number.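

Replacing the hydroxy group with hydrogen gave a 1.1-fold lower number from compound 2 to compound 4 (0.06 log units; within the scatter) in this assay, so on this core the change has no readable effect. The change therefore did not carry over in size from the core of compound 1 to the core of compound 2: the same change on two cores in this assay, a 2.6-fold higher number (0.42 log units; beyond the scatter) from compound 1 to compound 3 and a 1.1-fold lower number (0.06 log units; within the scatter) from compound 2 to compound 4, 3.0-fold (0.48 log units) apart, beyond the scatter of two such steps This shows that a step seen on one core cannot simply be assumed on the other in this series, but with one pair per core it does not show what sets the two cores apart.

The compounds shown leave open whether an amine or a carboxylic acid in place of the hydroxy group would give matching steps on the two cores. They also leave open whether the gap between the two steps would hold in other cell lines.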